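Compound 1 and its 2-nitro-1H-imidazol-1-yl counterpart

A few compounds are considered here, and "the series" means these few. Any claim that something is new, unique, unknown or untested is made for them only; others in the source may bear on it.

Measured in an ADME assay on L6 cells (Rattus norvegicus) for inhibition, read by resazurin assay, with a stated time of 72 h; a higher number here means a weaker inhibitor, a lower number a stronger inhibitor:
- compound 1 `O=C(Cn1cncn1)Nc1ccc(Oc2ccc(Cl)cc2)cc1`: 137000 nM
- compound 2 `O=C(Cn1cnc([N+](=O)[O-])n1)NC1CCN(Cc2ccccc2)CC1`: 114000 nM

The numbers for compound 1 and compound 2 lie within the usual scatter of each other, so neither stands apart. Compound 3 `O=C(Cn1ccnc1[N+](=O)[O-])Nc1ccc(Oc2ccc(Cl)cc2)cc1` keeps the core of compound 1 and carries 2-nitro-1H-imidazol-1-yl in place of 1H-1,2,4-triazol-1-yl on a saturated chain carbon bound to a carbonyl carbon. Within the data shown here, no measured pair shows this change, so the expectation is uncertain. A moderate move towards a lower number in this assay is expected, an estimated 2.3-fold lower number from compound 1 to compound 3 (0.36 log units; beyond the scatter). The estimate for compound 3 is 60000 nM, with an expected range from 15000 nM to 200000 nM.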

Compound 3, half-maximal inhibitory concentration: 127000 nM
Estimate against measurement, compound 3: 2.1-fold (0.33 log units) below; the range from low to high includes it.
By their numbers in this assay, from the lowest: compounds 2, 3 and 1 (each within the scatter of the next).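

In this assay, among these compounds, the exchange of 1H-1,2,4-triazol-1-yl for 2-nitro-1H-imidazol-1-yl on a saturated chain carbon bound to a carbonyl carbon gives a 1.1-fold lower number from compound 1 to compound 3 (0.03 log units; within the scatter) and is the first direct reading of a change at this position. On the core of compound 1, the two groups cannot be told apart in this assay. Nothing available explains this result. Still open, going by these compounds, is whether an amine or a carboxylic acid at this position, on the same core, would give a number beyond the scatter of compound 1.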